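Methoxy for Methyl: An Expected Response for Compound 4

A few compounds are considered here, and "the series" means these few. Any claim that something is new, unique, unknown or untested is made for them only; others in the source may bear on it.

Compound 1: `Cc1cnc(N2CCC(c3coc4c(N5CCc6cc(S(C)(=O)=O)ccc65)ncnc34)CC2)nc1` gives 159%
Compound 2: `CCc1cnc(N2CCC(c3coc4c(N5CCc6cc(S(C)(=O)=O)ccc65)ncnc34)CC2)nc1` gives 154%
Compound 3: `CS(=O)(=O)c1ccc2c(c1)CCN2c1ncnc2c(C3CCN(c4ncc(O)cn4)CC3)coc12` gives 145%

These three compounds share one core and were tested in a functional assay on cells for agonist activity at Glucose-dependent insulinotropic receptor (Homo sapiens), read by a luciferase reporter, with a stated time of 4 h; on this read-out higher numbers stand for larger maximal responses and lower numbers for smaller maximal responses. Compound 1 shows the largest number of the three, though only its step to compound 3 exceeds the usual scatter: a number 14 percentage points lower from compound 1 to compound 3 (beyond the scatter). The other two steps stay within the scatter: a number 5 percentage points lower from compound 1 to compound 2 (within the scatter), and a number 9 percentage points lower from compound 2 to compound 3 (within the scatter).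

Compound 4, `COc1cnc(N2CCC(c3coc4c(N5CCc6cc(S(C)(=O)=O)ccc65)ncnc34)CC2)nc1`, has not yet been measured. It differs from compound 1 in a single place: methoxy in place of methyl on an aromatic carbon.

For the measured compounds named here, two measured steps bear on this change. The closest comparison is the step from compound 1 to compound 3, where a different group took the place of the same methyl on the same aromatic carbon and the maximal response fell modestly. The step from compound 1 to compound 2 shows that adding one carbon at a saturated position changed little. On this basis the change to methoxy is expected to lower the response slightly, if at all, with the expected step being a number 9 percentage points lower from compound 1 to compound 4 (within the scatter).

Compound 4 is therefore estimated to give about 150%, with a likely range from 135% to 165%.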

Compound 4, largest response reached (Emax), in percent of the reference or control that the assay uses: 186%
Estimate against measurement, compound 4: 36 percentage points below; measured number outside the range, above it.
By their numbers in this assay, from the lowest: compounds 3, 2 and 1 (each within the scatter of the next, the first and the last beyond it); then compound 4.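

Methoxy is the first group here to lift the maximal response at this pyrimidine position in this assay, giving a number 27 percentage points higher from compound 1 to compound 4 (beyond the scatter), whereas neither ethyl nor hydroxy gave a number beyond the scatter above that of compound 1. The result also separates methoxy from the two other groups tried in this place: methyl in place of the hydrogen on the oxygen gives a number 41 percentage points higher from compound 3 to compound 4 (beyond the scatter) and methoxy in place of ethyl gives a number 32 percentage points higher from compound 2 to compound 4 (beyond the scatter), so a free hydroxy and an all-carbon ethyl chain do not reproduce the effect. Compound 4 therefore lies beyond the scatter above all three other compounds, making methoxy the group with the largest maximal response among these four.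

These compounds leave open whether a longer ether such as ethoxy, or an amine such as dimethylamino, would hold or extend this higher response at the same position. They also offer no measurement that explains the higher response of compound 4, so the reason for the gain remains unknown.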